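The compounds below may be only part of what the source reports. "The series", "measured", "known", "first", "only" and "open" are said of these compounds alone.

Measured so far:
Compound 1, `OC(CCn1nc2c(Br)c(Br)c(Br)c(Br)c2n1)c1ccc(F)cc1`, gives 16% in a functional assay on MCF7 cells (Homo sapiens) for antiproliferative activity, read by MTT assay, with a stated time of 24 h, tested at 50 uM; on this read-out lower numbers stand for a stronger effect and higher numbers for a weaker effect at the one concentration tested.
Compound 2, `OC(CCn1nc2c(Br)c(Br)c(Br)c(Br)c2n1)c1ccc(Br)cc1`, gives 10% in this assay.

On these two numbers compound 2 stands lowest, with compound 1 within the scatter of it. Compound 3, `OC(CCn1nc2c(Br)c(Br)c(Br)c(Br)c2n1)c1ccc(Cl)cc1`, differs from compound 2 by chloro in place of bromo on an aromatic carbon. Among the measured compounds shown here, the only measured step that bears on this is the swap of one halogen for another at the same place, a number 6 percentage points lower from compound 1 to compound 2 (within the scatter), which stayed within the scatter. A step of similar size is expected here, a number 3 percentage points higher from compound 2 to compound 3 (within the scatter), not beyond the scatter. Compound 3 is therefore estimated at 13%, within a range from 5% to 22%.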

Compound 3, a percentage reported as activity, at one concentration (the size of the read-out at that concentration, not a potency): 19%
The estimate for compound 3 lay 6 percentage points below the measured number; the range from low to high includes it.
By their numbers in this assay, from the lowest: compounds 2, 1 and 3 (each within the scatter of the next).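

With a third halogen at this place on the aromatic ring, chloro for bromo gives a number 9 percentage points higher from compound 2 to compound 3 (within the scatter), and chloro for fluoro gives a number 3 percentage points higher from compound 1 to compound 3 (within the scatter). Fluoro, bromo and chloro therefore cannot be told apart here in this assay, so swapping one of these halogens for another has shown no clear change. No measurement is available that offers an explanation for these results.

On these data alone, whether a non-halogen group at this place, such as an amine or a carboxylic acid, would give a number beyond the scatter stays open.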